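A few compounds are considered here, and "the series" means these few. Any claim that something is new, unique, unknown or untested is made for them only; others in the source may bear on it.

Measured compounds in an assay on cell membranes for binding affinity to Fatty-acid amide hydrolase 1 (Rattus norvegicus); a higher number here means a weaker inhibitor, a lower number a stronger inhibitor:
- compound 1 `Cc1ccc(-c2cccc(OC(=O)NC3CCCCC3)c2)cc1` gives 155 nM
- compound 2 `NC(=O)c1ccc(-c2cccc(OC(=O)NC3CCCCC3)c2)cc1` gives 5910 nM
- compound 3 `O=C(NC1CCCCC1)Oc1cccc(-c2cccc(Oc3ccccc3)c2)c1` gives 420 nM

Compound 3 stands second highest of the three numbers in this assay; its nearest neighbour is compound 1, the furthest compound 2, and both gaps lie beyond the scatter.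

Compound 4 `NS(=O)(=O)c1cccc(-c2cccc(OC(=O)NC3CCCCC3)c2)c1` is not yet measured. It differs from compound 3 by sulfamoyl in place of phenoxy on an aromatic carbon.

Among the measured compounds shown here, only one measured step bears on this change. The step of a 38-fold higher number from compound 1 to compound 2 (1.58 log units; beyond the scatter) replaced a methyl on the aromatic carbon with a carbamoyl, a group that, like sulfamoyl, brings a hydrogen-bond donor and hydrogen-bond acceptors. Compound 3 carries a phenoxy at the corresponding place, a ring without a hydrogen-bond donor, and the change to sulfamoyl is judged to follow the same direction. A large step upward in this assay is therefore expected, though the group and its place on the ring differ from those of compound 2, so the size is uncertain.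

Compound 4 is estimated at 4000 nM, range 1000 nM to 16000 nM, an expected step of a 9.5-fold higher number from compound 3 to compound 4 (0.98 log units; beyond the scatter).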

Compound 4, half-maximal inhibitory concentration: 26.5 nM
Compound 4: the middle estimate sits 150-fold (2.18 log units) above what was measured, and the stated range ends above it.
By their numbers in this assay, from the lowest: compound 4; then compound 1; then compound 3; then compound 2.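

In this assay, sulfamoyl in place of phenoxy, on an aromatic carbon meta to a large group, gives a 16-fold lower number from compound 3 to compound 4 (1.20 log units; beyond the scatter), so a group carrying a hydrogen-bond donor can stand at this place with a lower number than the phenoxy it replaces. The earlier carbamoyl change, a 38-fold higher number from compound 1 to compound 2 (1.58 log units; beyond the scatter), therefore sets no rule for donor-bearing groups on this ring: the two changes run in opposite directions, with different groups leaving and entering. Nothing measured here bears on why the number falls.

The compounds shown do not separate the loss of phenoxy from the arrival of sulfamoyl, as none has a plain hydrogen at this place. Also open, on these data alone, is how a carbamoyl, a methylsulfonyl or a carboxylic acid at this same place would compare with sulfamoyl.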